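Swapping a fused bicyclic amine for a simple pyrrolidine

The source may report more compounds than this note shows. Statements on the series, on what has been measured and on what is new or still open speak of the compounds shown alone.

Measured compounds:
- compound 1, `Nc1ccccc1NC(=O)c1ccc(CSC(=S)N2CCN(c3ccccc3)CC2)cc1`: 42.3%
- compound 2, `Nc1ccccc1NC(=O)c1ccc(CSC(=S)N2CCc3ccccc32)cc1`: 44%
- compound 3, `Nc1ccccc1NC(=O)c1ccc(CSC(=S)N2CCN(Cc3cccnc3)CC2)cc1`: 37.7%

All three share one core and differ only in the amine attached to the thiocarbonyl carbon. In a functional assay on MGC-803 cells (Homo sapiens) for antiproliferative activity, read by CCK-8 assay, with a stated time of 72 h, tested at 2 uM (on this read-out lower numbers stand for a weaker effect and higher numbers for a stronger effect at the one concentration tested), compound 2 gives the top figure of the three, but its gaps to compound 1 and compound 3 both lie within the usual scatter, so the three cannot be ranked against each other. Within the data shown here, the one measured step, a number 4.6 percentage points lower from compound 1 to compound 3 (within the scatter), is also within the scatter.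

Compound 4, `Nc1ccccc1NC(=O)c1ccc(CSC(=S)N2CCCC2)cc1`, is the next compound. Compared with compound 2 the change is pyrrolidin-1-yl in place of 2,3-dihydro-1H-indol-1-yl on a thiocarbonyl carbon. Among the measured compounds shown here, no measured step touches this kind of exchange; the single step available concerns a substituent on a ring nitrogen of a different amine, and it showed no effect beyond the scatter. With nothing pointing either way, no step beyond the scatter is expected in this assay from compound 2 to compound 4, so a number 5 percentage points lower from compound 2 to compound 4 (within the scatter) is the expected step. Compound 4 is therefore estimated at 39%, within a range of 26% to 52%.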

Compound 4, a percentage reported as inhibition, at one concentration (the size of the read-out at that concentration, not a potency): 27%
Estimate against measurement, compound 4: 12 percentage points above; low and high end bracket the measured number.
By their numbers in this assay, from the lowest: compound 4; then compounds 3, 1 and 2 (each within the scatter of the next).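

In this assay, among these compounds, the amine on the thiocarbonyl carbon can matter: the step of a number 17 percentage points lower from compound 2 to compound 4 (beyond the scatter) is the first one here to go beyond the scatter, unlike the step of a number 4.6 percentage points lower from compound 1 to compound 3 (within the scatter). The exchange removes the six-membered aromatic ring of carbon only and keeps the five-membered non-aromatic ring with its nitrogen, so these two compounds differ by that aromatic ring alone. No outside measurement is at hand to explain the lower number.

From the compounds shown here alone, it remains open whether any aromatic ring in this amine would restore the higher number, or whether the count of heavy atoms alone tracks it. A piperidin-1-yl group, or an open-chain amine such as diethylamine, on the same thiocarbonyl carbon would help separate these two readings.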